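The source may hold more compounds than are shown below. What is called first, only, known or untested is meant among the compounds shown, and "the series" means these compounds.

Series notes. Compound 1 `OC[C@H]1OC(n2cnc3c(Nc4ccccc4)nccc32)[C@H](O)[C@@H]1O` in a functional assay on EL4 cells (Mus musculus) for inhibition, tested at 100 uM (on this read-out lower numbers stand for less inhibition and higher numbers for more inhibition at the one concentration tested (going by the name of the read-out)), gives 10%. Compound 2 `OC[C@H]1O[C@@H](n2cnc3c(NCc4ccccc4)nccc32)C[C@@H]1O` in this assay gives 8%, and compound 3 `OCCNc1nccc2c1ncn2C1O[C@H](CO)[C@@H](O)[C@H]1O` gives 6%. Compound 2 stands within the scatter of both compound 1 and compound 3, so the three numbers cannot be told apart. Within the data shown here, the one recorded single-point step, a number 4 percentage points lower from compound 1 to compound 3 (within the scatter), stays within the scatter.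

Compound 4 `Nc1nccc2c1ncn2[C@H]1C[C@H](O)[C@@H](CO)O1` is to be measured in this assay. It differs from compound 2 by hydrogen in place of benzyl on a nitrogen on an aromatic ring. Among the measured compounds shown here, no measured step strips this nitrogen down to hydrogen, so nothing bears directly on the change; the only comparable step, the swap on the same nitrogen between compound 1 and compound 3, lay within the scatter, and all three measured compounds show weak inhibition whatever the substituent carried there. The expectation is therefore a step from compound 2 to compound 4 that stays within the scatter, no change at the digits printed from compound 2 to compound 4 (within the scatter). Compound 4 is estimated at 8%, with a range from 0% to 20%.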

Compound 4, a percentage reported as inhibition, at one concentration (the size of the read-out at that concentration, not a potency): 89%
The estimate for compound 4 lay 81 percentage points below the measured number, outside the stated range (above it).
By their numbers in this assay, from the lowest: compounds 3, 2 and 1 (each within the scatter of the next); then compound 4.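

Among these compounds, at the nitrogen on the aromatic ring, benzylamino to amino gives the first change beyond the scatter in this assay, with a number 81 percentage points higher from compound 2 to compound 4 (beyond the scatter). The earlier swap at this nitrogen, a number 4 percentage points lower from compound 1 to compound 3 (within the scatter), had suggested that the substituent made little difference, but that step compared two substituted nitrogens on a different sugar; the new step shows that, on the core of compound 2, the free amino form gives a far higher number than the benzyl form. No data in hand explain the size of this step.

On these data alone, it remains open whether a methyl or ethyl group on this nitrogen keeps the high number or already brings it down to the level of compound 2. As far as these compounds go, it is also open whether the free amino group gives a similar number on the sugar of compound 1, which carries an additional hydroxyl.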